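The source may hold more compounds than are shown below. What is called first, only, known or untested is meant among the compounds shown, and "the series" means these compounds.

Compound 1 `COc1ccc(/C=C/c2cc(/C=C/c3ccc(OC)cc3)nc(OCCCCCBr)n2)cc1` is the reference point of the series. In a functional assay on A549 cells (Homo sapiens) for cytotoxicity, read by fluorescence and resazurin assay, with a stated time of 48 h (on this read-out lower numbers stand for stronger inhibition and higher numbers for weaker inhibition), compound 1 returns only a limit, > 20000 nM. Compound 2 `COc1cc(/C=C/c2cc(/C=C/c3cc(OC)c(OC)c(OC)c3)nc(OCCCCCBr)n2)cc(OC)c1OC` likewise returns only a limit in this assay, > 20000 nM. Both values share (the limit of > 20000 nM in this assay, at which 2 of the 2 values shown sit), so compound 1 cannot be set apart from compound 2 on the numbers shown. Compound 3 `COc1ccc(/C=C/c2cc(/C=C/c3ccc(OC)cc3)nc(OCCCCCCBr)n2)cc1` differs from compound 1 by bromomethyl in place of bromo on a saturated chain carbon, five bonds along the chain from an oxygen on an aromatic ring. For the measured compounds named here, with no measured step, the change from compound 1 to compound 3 is expected to stay within the scatter, a step that the limit leaves unreadable from compound 1 to compound 3. Compound 3 is therefore estimated at 30000 nM in this assay, in a range from 15000 nM to 80000 nM, most probably again reported as a limit.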

Compound 3, half-maximal inhibitory concentration: > 20000 nM
Compound 3: only a limit was reported (the forecaster's own chance of this, stated with the estimate: 80%); the middle value lies beyond the limit too.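

No step can be read from compound 1 to compound 3, as both return only limits: the limit of > 20000 nM in this assay, at which 3 of the 3 values shown sit. The compounds shown leave open whether any change to the bromoalkyl chain or the methoxy groups brings a numerical value in this assay.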